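Replacing a Sulfur Link in Two Related Cores

The source may hold more compounds than are shown below. What is called first, only, known or untested is meant among the compounds shown, and "the series" means these compounds.

Compound 1 `CCOC(=O)c1c(CSc2nccn2C)nc2cc(OC)c(OC)cc2c1-c1ccc(OC)c(OC)c1` and compound 3 `CCOC(=O)c1c(CCc2nccn2C)nc2cc(OC)c(OC)cc2c1-c1ccc(OC)c(OC)c1` share one core and differ only by (1-methyl-1H-imidazol-2-yl)methyl in place of (1-methyl-1H-imidazol-2-yl)sulfanyl on a saturated chain carbon bound to an aromatic carbon. In a functional assay on the whole organism for inhibition, with Rattus norvegicus as the target, at a dose of 50 mg/kg by the oral route (a higher number here means more inhibition at the dose given (going by the name of the read-out), a lower number less inhibition), compound 1 gives 60%, and compound 3 gives 75%, so a number 15 percentage points higher from compound 1 to compound 3 (beyond the scatter). Compound 2 `COc1ccc(-c2nc(CSc3nccn3C)nc3cc(OC)c(OC)cc23)cc1OC` carries a second core; how it differs from compound 1 is not broken down here. In this assay compound 2 reaches only a limit, < 50%, not a measured number, as the limit of < 50% in this assay, at which 1 of the 3 values shown sits, records. Compound 4 `COc1ccc(-c2nc(CCc3nccn3C)nc3cc(OC)c(OC)cc23)cc1OC` is not yet measured and differs from compound 2 by (1-methyl-1H-imidazol-2-yl)methyl in place of (1-methyl-1H-imidazol-2-yl)sulfanyl on a saturated chain carbon bound to an aromatic carbon, the same change as in the first pair, at the same place. For compound 4 a step of a number no lower from compound 2 to compound 4 (the limit leaves the size open) is expected, because the measured pair shows a number 15 percentage points higher from compound 1 to compound 3 (beyond the scatter). Compound 2 offers only a limit, so the starting point is uncertain. Compound 4 is expected at 50%, within 30% to 68%.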

Compound 4, a percentage reported as inhibition, in the whole organism at one dose (the size of the read-out at that dose, not a potency): 71%
Estimate against measurement, compound 4: 21 percentage points below, and the stated range ends below it.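

In this assay, the change from (1-methyl-1H-imidazol-2-yl)sulfanyl to (1-methyl-1H-imidazol-2-yl)methyl gives a number at least 21 percentage points higher from compound 2 to compound 4 (beyond the scatter). Set beside the result on the first core, the two steps read: the same change on two cores in this assay, a number 15 percentage points higher (beyond the scatter) from compound 1 to compound 3 and a number at least 21 percentage points higher (beyond the scatter) from compound 2 to compound 4; the limit leaves it open whether they differ So the change moves the read-out in the same direction on both cores, but these two pairs cannot show whether the size of the step carries over, or whether the direction would hold on any further core.

The compounds shown leave open what other links in the same chain would do, such as an ether oxygen or an amine nitrogen in place of the sulfur, or a longer chain between the core and the imidazole. Going by these compounds, they also give inhibition at a single dose only, so how potency compares across the compounds remains open.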